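Azole Replacements for Thiophene in a Urea Series

The source may report more compounds than this note shows. Statements on the series, on what has been measured and on what is new or still open speak of the compounds shown alone.

Compound 1 `Cc1cc(C)c(NC(=O)N(Cc2ccc(-c3cccs3)cc2)C2CCCCCC2)c(C)c1` gives 0.28 mg/kg in a functional assay on a cell-free system (plasma) with sterol O-acyltransferase, Soat (Rattus norvegicus) as the target; a higher number here means that more compound is needed for the effect, a lower number that less compound is needed.
Compound 2 `Cc1cc(C)c(NC(=O)N(Cc2ccc(-n3cccn3)cc2)C2CCCCCC2)c(C)c1` gives > 1 mg/kg in this assay, a limit of the assay.
Compound 3 `Cc1cc(C)c(NC(=O)N(Cc2ccc(-c3cc[nH]n3)cc2)C2CCCCCC2)c(C)c1` gives > 1 mg/kg in this assay, likewise a limit.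

Compound 3 therefore stands at the limit rather than at a number, and the same holds for compound 2 (the limit of > 1 mg/kg in this assay, at which 2 of the 3 values shown sit). Within the data shown here, the only measured number in the set belongs to compound 1, and both steps away from it, an at least 3.5-fold higher number from compound 1 to compound 2 (0.55 log units; beyond the scatter) and an at least 3.5-fold higher number from compound 1 to compound 3 (0.55 log units; beyond the scatter), are at least modest and beyond the scatter; the step that the two limits leave unreadable from compound 2 to compound 3 cannot be read, since both ends are limits.

Compound 4 `Cc1cc(C)c(NC(=O)N(Cc2ccc(-n3cncn3)cc2)C2CCCCCC2)c(C)c1` is related to compound 3 by the change (1H-1,2,4-triazol-1-yl in place of 1H-pyrazol-3-yl on an aromatic carbon). Among the measured compounds shown here, the two azole analogues already measured, compound 2 and compound 3, both sit at the limit in this assay, and no step of readable size separates one azole from another. Compound 4 is therefore expected to behave like them, with an estimated value of 2 mg/kg in this assay, within a range of 0.7 mg/kg to 6 mg/kg. The expected step that the limit leaves unreadable from compound 3 to compound 4 is thus none beyond the scatter, and a limit rather than a number is the likelier report.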

Compound 4, dose for half-maximal effect: > 1 mg/kg
Compound 4: only a limit was reported; the forecaster's own chance of this, stated with the estimate: 75%; the middle value lies beyond the limit too.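

Replacing 1H-pyrazol-3-yl, with 1 hydrogen-bond donor, by 1H-1,2,4-triazol-1-yl, with 0 hydrogen-bond donors and 3 hydrogen-bond acceptors, on this aromatic carbon para to a large group still leaves compound 4 at a limit of the assay and not at a number, > 1 mg/kg in this assay. Thiophen-2-yl to 1H-1,2,4-triazol-1-yl gives an at least 3.5-fold higher number from compound 1 to compound 4 (0.55 log units; beyond the scatter), so all three azoles shown now stand apart from the thiophene, with none among them going against this. The steps among compound 2, compound 3 and compound 4 cannot be read, so the azoles cannot be ranked: the limit of > 1 mg/kg in this assay, at which 3 of the 4 values shown sit.

As far as these compounds go, how far beyond the limit these azoles lie stays open. Also open, from the compounds shown here alone, is whether the measured value of compound 1 is particular to thiophen-2-yl or would be shared by a phenyl or furan-2-yl group at this place.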